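Pyrrolidine to Imidazole on a Butynyl Carbamate Chain

This account rests on a few compounds, and the source may have more. Where it says the series, first, only, none or still open, it means among the compounds named here.

Measured so far in a functional assay on the whole organism for antagonist activity, with Mus musculus as the target; on this read-out higher numbers stand for an effect only at larger amounts of compound and lower numbers for an effect already at smaller amounts:
- compound 1, `COC(=O)N(C)C(C)C#CCN1CCCC1`: > 100 mg/kg, a limit of the assay
- compound 2, `COC(=O)N(C)C(C)C#CCn1ccnc1`: > 100 mg/kg, a limit of the assay
- compound 3, `CCOC(=O)N(C)CC#CCN1CCCC1`: > 100 mg/kg, a limit of the assay

None of the three gives a number. In this assay compound 1 stops at a limit, > 100 mg/kg. Compound 2 likewise stops at a limit, > 100 mg/kg. Compound 3 also stops at a limit, > 100 mg/kg. So the limit of > 100 mg/kg in this assay, at which 3 of the 3 values shown sit, is the whole of what is known, and the one change that can be followed between measured compounds, (1H-imidazol-1-yl in place of pyrrolidin-1-yl on a saturated chain carbon bound to a triple-bonded carbon), gives a step that the two limits leave unreadable from compound 1 to compound 2.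

Compound 1 and compound 3 are built from the same atoms joined differently; the difference between the two cores is not broken down here.

Compound 4, `CCOC(=O)N(C)CC#CCn1ccnc1`, is not yet measured. It stands to compound 3 as compound 2 stands to compound 1: 1H-imidazol-1-yl in place of pyrrolidin-1-yl on a saturated chain carbon bound to a triple-bonded carbon, at the same place, so it is the same change. Going by the values given here, since the measured version of that change is unreadable, and every value so far sits at the limit, the expectation for the step from compound 3 to compound 4 in this assay is a step that the limit leaves unreadable from compound 3 to compound 4, which is to say no readable movement. Compound 4 is therefore expected to give about 150 mg/kg, with a plausible span from 50 mg/kg to 1000 mg/kg, and most likely the assay will again report only a limit rather than a number.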

Compound 4, dose for half-maximal effect: > 100 mg/kg
Compound 4 gave a limit, no number (the forecaster's own chance of this, stated with the estimate: 85%); the middle value lies beyond the limit too.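

In this assay compound 4 gives > 100 mg/kg, which is a limit of the assay and not a number. No step can be read between compound 3 and compound 4, and all that is known comes down to one finding: the limit of > 100 mg/kg in this assay, at which 4 of the 4 values shown sit. The compounds shown leave open whether any of them has an effect at a measurable dose, and whether 1H-imidazol-1-yl in place of pyrrolidin-1-yl changes anything in this assay.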